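Resolving the ring stereocentre in the amine series

The compounds below may be only part of what the source reports. "The series", "measured", "known", "first", "only" and "open" are said of these compounds alone.

Measured so far:
compound 1 `CCN(CCCCc1cn(-c2ccc(F)cc2)c2ccccc12)C1CCc2c1ccc(OC)c2OC` — 59.2 nM
compound 2 `COc1ccc2c(c1OC)CCC2NCCCCc1cn(-c2ccc(F)cc2)c2ccccc12` — 215 nM
compound 3 `COc1ccc(CNCCCCc2cn(-c3ccc(F)cc3)c3ccccc23)cc1` — 129 nM

In an assay on membranes from brain for displacement of a labelled ligand from Sigma non-opioid intracellular receptor 1 (Cavia porcellus), read by radioligand binding (a lower number here means a stronger inhibitor, a higher number a weaker inhibitor), compound 1 gives the lowest of the three numbers. Its nearest neighbour is compound 3, which gives 129 nM in this assay, a gap beyond the scatter. Within the data shown here, the one step that can be followed within the set, a 3.6-fold higher number from compound 1 to compound 2 (0.56 log units; beyond the scatter), is modest and concerns the substituent on the amine nitrogen.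

Compound 4 `CCN(CCCCc1cn(-c2ccc(F)cc2)c2ccccc12)[C@H]1CCc2c1ccc(OC)c2OC` differs from compound 1 only in stereochemical drawing: the two compounds have the same atoms and bonds; at least one stereo element is drawn with a configuration in one of them and without one in the other: 1 of 1 stereo elements differ; a stereocentre at a saturated ring carbon is drawn without a configuration in compound 1 and S in compound 4. Among the measured compounds shown here, no measured step touches a stereo element, so the size and direction of the change cannot be read from the set. If compound 1 represents both configurations together, the single S form could give a somewhat lower number than compound 1 in this assay if it is the favoured configuration, or a clearly higher number if it is not. The expected step of a 1.5-fold lower number from compound 1 to compound 4 (0.17 log units; within the scatter) is therefore small, within the scatter, with a wide range to allow for either outcome. Compound 4 is expected to give 40 nM in this assay, estimated between 12 nM and 160 nM.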

Compound 4, inhibition constant: 50.8 nM
For compound 4 the middle estimate is 1.3-fold (0.10 log units) below the measured one; measured number inside the range.
By their numbers in this assay, from the lowest: compounds 4 and 1 (each within the scatter of the next); then compounds 3 and 2 (each within the scatter of the next).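

In this assay, among these compounds, the first step at the stereocentre is a 1.2-fold lower number from compound 1 to compound 4 (0.07 log units; within the scatter), so drawing the saturated ring carbon as S leaves the number unchanged within the scatter. The earlier compounds shown here showed only that the substituent on the amine nitrogen matters, with a 3.6-fold higher number from compound 1 to compound 2 (0.56 log units; beyond the scatter); this new step shows that the S form keeps the level of compound 1 and that, at this position, defining the configuration as S brings no measurable change. The comparison is a clean one, with no other structural difference to weigh: the fact that one of compounds 1 and 4 is drawn with a defined configuration and the other without, at the place where they differ

Going by these compounds, without the R form in hand, it remains open whether that configuration would give a similar number or a clearly higher one, and so whether the stereocentre has any influence on the number at all. On these data alone, it is also open whether a propyl or cyclopropylmethyl group on the amine nitrogen in place of ethyl would change the number of the S form, or whether a longer chain in place of the butyl linker would do so.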